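The source may hold more compounds than are shown below. What is called first, only, known or untested is meant among the compounds shown, and "the series" means these compounds.

Of the compounds shown here, three that share one core have been measured in an assay on CHO cells for positive allosteric modulation of metabotropic glutamate receptor 2 (Homo sapiens), read by scintillation counting, with a stated time of 30 min; on this read-out lower numbers stand for an effect already at smaller amounts and higher numbers for an effect only at larger amounts of compound. Compound 1 `FC(F)(F)c1c(CN2CCCC(c3ccccc3)C2)ccn2c(CC3CC3)nnc12` gives 65 nM. Compound 2 `FC(F)(F)c1c(CN2CCC(c3ccccc3Cl)CC2)ccn2c(CC3CC3)nnc12` gives 13.5 nM, and compound 3 `Fc1cccc(F)c1C1CCN(Cc2ccn3c(CC4CC4)nnc3c2C(F)(F)F)CC1` gives 9.7 nM. Compound 3 carries the lowest of the three numbers; its gap to compound 2 lies within the scatter, while its gap to compound 1 lies beyond it. Going by the values given here, the only measured step that alters a single place is a 1.4-fold lower number from compound 2 to compound 3 (0.14 log units; within the scatter), an exchange of one aromatic ring for another on the same saturated ring carbon.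

Compound 4 `Fc1ccc(COC2CCN(Cc3ccn4c(CC5CC5)nnc4c3C(F)(F)F)CC2)c(F)c1` awaits measurement. Its change from compound 3 is (2,4-difluorobenzyl)oxy in place of 2,6-difluorophenyl on a saturated ring carbon. Among the compounds with values here, the entering group is larger than the leaving one and brings one hydrogen-bond acceptor; no measured step covers a change of this kind, so the single small aryl exchange is only a loose guide. Compound 4 is therefore expected to give about 20 nM, with a range from 6 nM to 70 nM. The expected step is a 2.1-fold higher number from compound 3 to compound 4 (0.31 log units; beyond the scatter), a modest rise that may not stand out from the scatter.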

Compound 4, half-maximal effective concentration: 57 nM
Beside the measured number, compound 4's estimate is 2.9-fold (0.45 log units) below it; measured number inside the range.
By their numbers in this assay, from the lowest: compounds 3 and 2 (each within the scatter of the next); then compounds 4 and 1 (each within the scatter of the next).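

Up to this point, the only step at this position was an exchange of one aromatic ring for another directly on the saturated ring carbon, and it stayed within the scatter. Putting (2,4-difluorobenzyl)oxy there gives a clearer change: a 5.9-fold higher number from compound 3 to compound 4 (0.77 log units; beyond the scatter) and a 4.2-fold higher number from compound 2 to compound 4 (0.63 log units; beyond the scatter) are both beyond the scatter but still modest, so the position responds to this larger group without the effect being lost. Nothing measured here explains the rise.

The entering group adds an oxygen and a carbon and also carries its two fluorines in a different pattern, and the compounds shown cannot tell these changes apart. A benzyl group without the oxygen, or a 2,6-difluorobenzyloxy group, would separate them.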